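The compounds below may be only part of what the source reports. "The series", "measured", "known", "first", "only" and "open" are said of these compounds alone.

Measured so far in an assay for inhibition of Polyunsaturated fatty acid 5-lipoxygenase (Homo sapiens), read by HPLC, with a stated time of 10 min; on this read-out higher numbers stand for weaker inhibition and lower numbers for stronger inhibition:
- compound 1 `CCCCCCC(Sc1nc(Cl)cc(Nc2nc(-c3ccc(C)cc3)cs2)n1)C(=O)O` gives 3000 nM
- compound 2 `CCCCCCC(Sc1nc(Cl)cc(Nc2nc(-c3ccc(-c4ccccc4)cc3)cs2)n1)C(=O)O` gives 600 nM

Of these two numbers, compound 2 has the lower one, separated from compound 1 by more than the usual scatter. Compound 3 `CCCCCCC(Sc1nc(Cl)cc(Nc2nc(-c3ccc(OC)cc3)cs2)n1)C(=O)O` has not been measured yet. It differs from compound 2 in a single place: methoxy in place of phenyl on an aromatic carbon. Within the data shown here, only one measured step bears on this position. There, a 5.0-fold lower number from compound 1 to compound 2 (0.70 log units; beyond the scatter) was seen, meaning that the six-carbon phenyl gave a markedly lower number than the one-carbon methyl. A methoxy, with two heavy atoms, is again a small group, so the change from compound 2 to compound 3 is expected to undo much of what that step brought and to move the number back toward that of compound 1, while a methoxy is not a methyl and this remains uncertain. The expected step is a 3.3-fold higher number from compound 2 to compound 3 (0.52 log units; beyond the scatter). The estimate for compound 3 is 2000 nM, with a range from 700 nM to 6000 nM.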

Compound 3, half-maximal inhibitory concentration: 1800 nM
Compound 3: middle estimate off by 1.1-fold (0.05 log units), on the high side; measured number inside the range.
By their numbers in this assay, from the lowest: compound 2; then compounds 3 and 1 (each within the scatter of the next).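

In this assay, methoxy in place of phenyl gives a 3.0-fold higher number from compound 2 to compound 3 (0.48 log units; beyond the scatter) and so gives up most of what the phenyl had gained, which shows that the low number of compound 2 does not carry over to just any group at this position. Methoxy in place of methyl gives a 1.7-fold lower number from compound 1 to compound 3 (0.22 log units; within the scatter) and thus leaves compound 1 and compound 3 indistinguishable, so among these three compounds only the 4-phenylphenyl group stands apart. No measurement at hand explains why the phenyl behaves differently.

The compounds shown leave open whether the second ring's aromatic character or simply the number of atoms at this position matters. A cyclohexyl group or a longer chain such as hexyl in the same place would help separate these two readings.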